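The source may hold more compounds than are shown below. What is called first, only, known or untested is meant among the compounds shown, and "the series" means these compounds.

- compound 1 `NS(=O)(=O)c1ccc(C(=O)N/N=C(/CS(=O)(=O)c2ccccc2)c2ccc(F)cc2)cc1` at 620 nM
- compound 2 `NS(=O)(=O)c1ccc(C(=O)N/N=C\c2ccccc2)cc1` at 14900 nM

In a functional assay on MCF7 cells (Homo sapiens) for antiproliferative activity, read by MTT assay (a higher number here means a weaker inhibitor, a lower number a stronger inhibitor), compound 2 holds the higher number of the two, beyond the scatter from compound 1, and so is the weaker inhibitor of the pair. Compound 3 `NS(=O)(=O)c1ccc(C(=O)N/N=C\c2ccc(F)cc2)cc1` differs from compound 2 by fluoro in place of hydrogen on an aromatic carbon. Among the compounds with values here, no measured pair shows this change alone, so the expectation stays near compound 2 (14900 nM), with no step beyond the scatter and, if anything, a slightly lower number. The expected step is small (a 1.2-fold lower number from compound 2 to compound 3 (0.09 log units; within the scatter)). The estimated value for compound 3 is 12000 nM (range 5000 nM to 30000 nM).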

Compound 3, half-maximal inhibitory concentration: 9170 nM
Compound 3: middle estimate off by 1.3-fold (0.12 log units), on the high side, within the range that was stated.
By their numbers in this assay, from the lowest: compound 1; then compounds 3 and 2 (each within the scatter of the next).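

In this assay, fluoro in place of hydrogen on the aromatic carbon para to a large group gives a 1.6-fold lower number from compound 2 to compound 3 (0.21 log units; within the scatter). Within the data shown here, this position therefore accepts fluoro, but the change alone gives no step that can be told from the scatter. No supporting data bear on this result.

Open, going by these compounds, is whether an amine, a carboxylic acid or methoxy at this position would give a step beyond the scatter. Also open, on these data alone, is what replacing fluoro with hydrogen would do in the core of compound 1.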